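The source may hold more compounds than are shown below. What is called first, only, known or untested is meant among the compounds shown, and "the series" means these compounds.

Compound 1 `Nc1nc(CN=C=S)c[se]1` is the weakest of three compounds measured in a functional assay on L1210 cells (Mus musculus) for antiproliferative activity (on this read-out higher numbers stand for weaker inhibition and lower numbers for stronger inhibition), where compound 1 gives 21000 nM, the highest number of the set. Compound 2 `CC(C)C(=O)Nc1nc(CN=C=S)cs1` gives 8200 nM and compound 3 `O=C(Nc1nc(CN=C=S)cs1)c1ccc(Cl)c(Cl)c1` gives 820 nM; each differs from compound 1 in more than one place, so neither gap is traced to a single change. Compound 4 `CC(C)C(=O)Nc1nc(CN=C=S)c[se]1` has not been measured. It differs from compound 1 by isopropylcarbonyl in place of hydrogen on a nitrogen on an aromatic ring. Going by the values given here, no single-change step between measured compounds exists, so the analyst leans on compound 2, whose value 8200 nM is the closest acylated comparator. The analyst expects the step from compound 1 to compound 4 to be a 2.6-fold lower number from compound 1 to compound 4 (0.42 log units; beyond the scatter), a modest fall beyond the scatter. For compound 4 the estimate is 8000 nM, between 3000 nM and 20000 nM.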

Compound 4, half-maximal inhibitory concentration: 28000 nM
For compound 4 the middle estimate is 3.5-fold (0.54 log units) below the measured one; the measured number lies above the stated range.
By their numbers in this assay, from the lowest: compound 3; then compound 2; then compounds 1 and 4 (each within the scatter of the next).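

In this assay, going by these compounds alone, the first single-change step on this core reads a 1.3-fold higher number from compound 1 to compound 4 (0.12 log units; within the scatter), so isopropylcarbonyl in place of hydrogen on a nitrogen on an aromatic ring shows no change beyond the scatter. The earlier compounds shown here could not show this, since none of them differed from another in one place only. No evidence at hand bears on this result. Going by these compounds, whether an acetyl group or a longer acyl chain on that nitrogen would also stay within the scatter remains open, as does whether the same exchange would read alike on another core.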